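A few compounds are considered here, and "the series" means these few. Any claim that something is new, unique, unknown or untested is made for them only; others in the source may bear on it.

Working notes on the series in a functional assay on HeLa cells (Homo sapiens) for inhibition, read by MTT assay, with a stated time of 48 h; a higher number here means a weaker inhibitor, a lower number a stronger inhibitor. Compound 1 (`CCOC(=O)C1=C(N/C=N/c2nnc(S(N)(=O)=O)s2)Nc2[nH]nc(C)c2C1c1ccc(N(C)C)cc1`) gives 26300 nM. Compound 2 (`CCOC(=O)C1=C(NN=C(C#N)C#N)Nc2[nH]nc(C)c2C1c1ccc(N(C)C)cc1`) gives 15200 nM. Compound 3 (`CCOC(=O)C1=C(N/C=N/c2ncc(-c3ccccc3)s2)Nc2[nH]nc(C)c2C1c1ccc(N(C)C)cc1`) gives 15400 nM. Compound 3 thus stands level with compound 2 and is not separated from compound 1, and all three numbers lie within the scatter of one another.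

Next for testing is compound 4 (`CCOC(=O)C1=C(N/C=N/c2ccccn2)Nc2[nH]nc(C)c2C1c1ccc(N(C)C)cc1`), which carries pyridin-2-yl in place of 5-phenyl-1,3-thiazol-2-yl on a double-bonded nitrogen.

Among the compounds with values here, two measured steps bear on this change. The closer one is made on the same double-bonded nitrogen, where 5-phenyl-1,3-thiazol-2-yl replaces 5-sulfamoyl-1,3,4-thiadiazol-2-yl: a 1.7-fold lower number from compound 1 to compound 3 (0.23 log units; within the scatter). The less direct one is made on an amine nitrogen: a 1.7-fold lower number from compound 1 to compound 2 (0.24 log units; within the scatter). Within the data shown here, neither step leaves the scatter, and no measured compound in this set carries pyridin-2-yl. No step beyond the scatter is therefore expected in this assay, and no direction is favoured.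

The expected step is a 1.1-fold higher number from compound 3 to compound 4 (0.04 log units; within the scatter). For compound 4 the estimated value is 17000 nM, with an expected range of 8500 nM to 34000 nM.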

Compound 4, half-maximal inhibitory concentration: 29200 nM
Compound 4: middle estimate off by 1.7-fold (0.23 log units), on the low side; the measured number falls inside the stated range.
By their numbers in this assay, from the lowest: compounds 2, 3, 1 and 4 (each within the scatter of the next).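

In this assay, the smaller pyridin-2-yl, in place of 5-phenyl-1,3-thiazol-2-yl, gives a step on the double-bonded nitrogen that still stays within the scatter: a 1.9-fold higher number from compound 3 to compound 4 (0.28 log units; within the scatter). The exchange of 5-sulfamoyl-1,3,4-thiadiazol-2-yl for pyridin-2-yl at that position gives a 1.1-fold higher number from compound 1 to compound 4 (0.05 log units; within the scatter), and the comparison with the ring-free group of compound 2 gives a 1.9-fold higher number from compound 2 to compound 4 (0.28 log units; within the scatter), so none of the four groups shown is separated from another, and a single six-membered aromatic ring serves here as well as the larger groups. No measurement at hand accounts for these numbers.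

Within the data shown here, whether any group on this nitrogen can move the number beyond the scatter remains open, since every step so far stays within it, and a simple phenyl ring or a pyridin-2-yl carrying an amine or a carboxylic acid would test that. It is also open whether this flat picture holds outside HeLa cells, as the compounds shown are compared in this one assay only.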